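Shifting the methoxy group: compound 3 to compound 4

This account rests on a few compounds, and the source may have more. Where it says the series, first, only, none or still open, it means among the compounds named here.

Compound 3 `COc1ccc(/C=C/C(=O)/C=C/c2ccc(OCc3cn(CCOc4cc(=O)oc5ccccc45)nn3)c(OC)c2)cc1` gives 78% in a functional assay on THP-1 cells (Homo sapiens) for inhibition, read by sulforhodamine B assay, with a stated time of 48 h, tested at 50 uM (a lower number here means less inhibition of growth, a higher number more inhibition of growth at the concentration tested), the second highest of the three numbers: compound 1 `COc1cc(/C=C/C(=O)/C=C/c2cc(OC)c(OC)c(OC)c2)ccc1OCc1cn(CCOc2cc(=O)oc3ccccc23)nn1` gives 99%, and compound 2 `COc1cc(/C=C/C(=O)/C=C/c2ccco2)ccc1OCc1cn(CCCCCOc2cc(=O)oc3ccccc23)nn1` gives 39%. Compound 4 `COc1cccc(/C=C/C(=O)/C=C/c2ccc(OCc3cn(CCOc4cc(=O)oc5ccccc45)nn3)c(OC)c2)c1` is not yet measured; it differs from compound 3 in one place: 3-methoxyphenyl in place of 4-methoxyphenyl on a double-bonded chain carbon bound to a double-bonded chain carbon. Among the compounds with values here, the only measured step at this position, a number 21 percentage points lower from compound 1 to compound 3 (beyond the scatter), involved a larger change of the aryl group and was modest. Within the data shown here, no measured pair tests a shift of a single methoxy group, so the change is expected to be of similar or smaller size, with a slightly lower number somewhat more likely than a higher one. For compound 4 the expected value is 70%, in the range 45% to 90%. The estimated step is a number 8 percentage points lower from compound 3 to compound 4 (within the scatter).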

Compound 4, percent growth inhibition at one concentration: 77%
For compound 4 the middle estimate is 7 percentage points below the measured one; the measured number falls inside the stated range.
By their numbers in this assay, from the lowest: compound 2; then compounds 4 and 3 (each within the scatter of the next); then compound 1.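

In this assay, within the data shown here, the step of a number 1 percentage points lower from compound 3 to compound 4 (within the scatter) is the first measured shift of a single methoxy group at this position, and it stays within the scatter, so 4-methoxyphenyl and 3-methoxyphenyl cannot be told apart here. The step of a number 22 percentage points lower from compound 1 to compound 4 (beyond the scatter) is a modest one beyond the scatter and closely matches the earlier step to the 4-methoxyphenyl compound, leaving 3,4,5-trimethoxyphenyl ahead of both. Nothing at hand explains these numbers.

Open, on these data alone, is whether an amine or a carboxylic acid in place of the methoxy group keeps the number in this range. Also open, as far as these compounds go, is whether two methoxy groups on the phenyl ring are enough to close the gap to compound 1.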